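The source may report more compounds than this note shows. Statements on the series, on what has been measured and on what is new or still open speak of the compounds shown alone.

Measured compounds: compound 1 `CNC(=O)c1ccc(NC(=O)[C@H]2CCCN2C(=O)C2(c3cccc(Cl)c3)CCCC2)cc1` gives 5.3 in a physicochemical assay for lipophilicity, at pH 7.4; on this read-out lower numbers stand for lower lipophilicity and higher numbers for higher lipophilicity; compound 2 `N#Cc1ccc(C2(C(=O)N3CCC[C@@H]3C(=O)Nc3ccc4[nH]ncc4n3)CCC2)cc1` gives 3.4; compound 3 `O=C(Nc1ccc2[nH]ncc2n1)[C@H]1CCCN1C(=O)C1(c2ccc(Cl)cc2)CCC1` gives 4.7.

Compound 3 stands second highest of the three numbers, nearest to compound 1 and furthest from compound 2. Compound 4 `COc1ccc(C2(C(=O)N3CCC[C@@H]3C(=O)Nc3ccc4[nH]ncc4n3)CCC2)cc1` differs from compound 3 by methoxy in place of chloro on an aromatic carbon. Going by the values given here, no measured step covers this exchange directly; the only step bearing on the same aromatic carbon is a number 1.30 log units higher from compound 2 to compound 3 (beyond the scatter), which shows that a change of this group moves the read-out strongly. Because that step a number 1.30 log units higher from compound 2 to compound 3 (beyond the scatter) was large, a step of moderate size downward is expected here, written as a number 0.70 log units lower from compound 3 to compound 4 (beyond the scatter). Compound 4 is therefore estimated at 4, with a range from 3.5 to 4.5.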

Compound 4, distribution coefficient: 3.9
Compound 4: middle estimate off by 0.10 log units, on the high side; the measured number falls inside the stated range.
By their numbers in this assay, from the lowest: compound 2; then compound 4; then compound 3; then compound 1.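

With the core held fixed, this assay now separates three groups at this aromatic carbon: methoxy in place of chloro gives a number 0.80 log units lower from compound 3 to compound 4 (beyond the scatter), and methoxy in place of cyano gives a number 0.50 log units higher from compound 2 to compound 4 (beyond the scatter). Methoxy therefore falls at neither end of the span, and all three groups stand apart by more than the scatter. Nothing at hand explains this order. As far as these compounds go, whether an amine, a carboxylic acid or ethoxy on this carbon would fall inside that span remains open, as does whether the order holds on the core of compound 1.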